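The compounds below may be only part of what the source reports. "The series", "measured", "known", "first", "only" and "open" are said of these compounds alone.

Compound 1 `O=C(Nc1ncc(Cc2ccc(F)cc2)s1)C1CCCCC1` — in an ADME assay on HepG2 2.2.15 cells (Homo sapiens) for cytotoxicity (on this read-out lower numbers stand for higher toxicity in this test and higher numbers for lower toxicity in this test), compound 1 gives > 50000 nM, a limit of the assay.
Compound 2 `O=C(Nc1ncc(Cc2ccc(Cl)cc2)s1)c1cccs1` — in this assay compound 2 gives > 50000 nM, again a limit of the assay.
Compound 3 `O=C(Nc1ncc(C(Oc2ccc3cc(Br)ccc3c2)c2ccc(Cl)cc2)s1)C1CCOCC1` — in this assay compound 3 is recorded as "not toxic" (no number reported), with no number.

Compound 3 therefore stands alongside the other two, not as a number but as a report of no toxicity, and the other two values shown are the limit of > 50000 nM in this assay, at which 2 of the 3 values shown sit. Within the data shown here, none of the three compounds reaches a measurable half-maximal cytotoxic concentration in this test, so there is no ordering among them and no measured step to lean on.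

The unmeasured compound 4 `CCc1ccc(S(=O)(=O)Nc2ncc(C(Oc3ccc4cc(Br)ccc4c3)c3ccc(Cl)cc3)s2)cc1` differs from compound 3 in one place: (4-ethylphenyl)sulfonyl in place of (oxan-4-yl)carbonyl on a nitrogen on an aromatic ring. Since every measured compound, however its amide is built, sits at or beyond the limit, a step from compound 3 to compound 4 in this assay is expected to be none beyond the scatter, with the most likely outcome again a limit rather than a number.

Compound 4 is accordingly estimated at 40000 nM in this assay, within a range from 10000 nM to 100000 nM.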

Compound 4, half-maximal cytotoxic concentration: > 50000 nM
Compound 4: a limit, no number (the forecaster's own chance of this, stated with the estimate: 70%); at least 1.2-fold (0.09 log units) between middle value and limit.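

In this assay compound 4 gives > 50000 nM, a limit of the assay. Compound 3 carries no number, so no step from compound 3 to compound 4 can be read, and the result joins the others: the limit of > 50000 nM in this assay, at which 3 of the 4 values shown sit.

The compounds shown leave open at what concentration, if any, each would turn toxic in this assay.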